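The compounds below may be only part of what the source reports. "The series", "measured", "known", "first", "only" and "open" are said of these compounds alone.

Measured compounds in an assay on striatum with sodium-dependent dopamine transporter (Rattus norvegicus) as the target; a lower number here means a stronger inhibitor, a higher number a weaker inhibitor:
- compound 1, `CN1CC[C@H](c2ccc(Cl)cc2)[C@@H](C(=O)OC(C)(C)C)C1`, with compound 1 giving 318 nM
- compound 2, `C=CCOC[C@H]1CN(C)CC[C@@H]1c1ccc(Cl)cc1`, with compound 2 giving 60 nM
- compound 3, `CCOC(=O)C[C@H]1CN(C)CC[C@@H]1c1ccc(Cl)cc1`, with compound 3 giving 79 nM

Compound 3 stands second highest of the three numbers in this assay: its nearest neighbour is compound 2, and the two lie within the scatter of each other (a 1.3-fold higher number from compound 2 to compound 3 (0.12 log units; within the scatter)), while compound 1 lies furthest away (a 4.0-fold lower number from compound 1 to compound 3 (0.60 log units; beyond the scatter)).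

Compound 4, `CN1CC[C@H](c2ccc(Cl)cc2)[C@@H](CC(=O)N(C)C)C1`, differs from compound 3 in one place: dimethylamino in place of ethoxy on a carbonyl carbon. Within the data shown here, none of the measured steps touches this exchange. The step of a 5.3-fold lower number from compound 1 to compound 2 (0.72 log units; beyond the scatter) and the step of a 4.0-fold lower number from compound 1 to compound 3 (0.60 log units; beyond the scatter) both replace the tert-butoxycarbonyl on the ring carbon by a chain, not the group on the carbonyl carbon, and the step of a 1.3-fold higher number from compound 2 to compound 3 (0.12 log units; within the scatter) swaps allyloxy for ethoxycarbonyl on the chain. The data therefore give no direct guide, and a step no larger than the scatter is expected in this assay, with a small lean toward a higher number.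

Compound 4 is thus estimated at 110 nM (range 35 nM to 350 nM), which is expected to mean a step of a 1.4-fold higher number from compound 3 to compound 4 (0.14 log units; within the scatter).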

Compound 4, inhibition constant: 16 nM
For compound 4 the middle estimate is 6.9-fold (0.84 log units) above the measured one; the measured number lies below the stated range.
By their numbers in this assay, from the lowest: compound 4; then compounds 2 and 3 (each within the scatter of the next); then compound 1.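

In this assay, among these compounds, the exchange of ethoxy for dimethylamino on a carbonyl carbon is the first change at this carbonyl, and it moves the number beyond the scatter (a 4.9-fold lower number from compound 3 to compound 4 (0.69 log units; beyond the scatter)). The (dimethylcarbamoyl)methyl chain also separates from the allyloxy compound (a 3.8-fold lower number from compound 2 to compound 4 (0.57 log units; beyond the scatter)), although compound 2 and compound 3 had stayed within the scatter of each other, and it gives the largest step in the set (a 20-fold lower number from compound 1 to compound 4 (1.30 log units; beyond the scatter)). No measurement shown here explains why this exchange has such an effect.

The compounds shown leave open whether other groups on this carbonyl carbon, such as methylamino, an unsubstituted amino group or pyrrolidine, or a carboxylic acid in place of the ester, would behave like dimethylamino. They also leave open whether dimethylcarbamoyl set directly on the ring carbon, or on a longer chain, would give a similar number.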